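Swapping an amide for a ketone on a shared core

A few compounds are considered here, and "the series" means these few. Any claim that something is new, unique, unknown or untested is made for them only; others in the source may bear on it.

Measured so far:
compound 1 `Cc1ccnc(-c2cnc(C(=O)CCCCCCc3ccccc3)o2)c1`: 0.6 nM
compound 2 `CNC(=O)c1cnc(C(=O)CCCCCCc2ccccc2)o1`: 7 nM

In an assay (Rattus norvegicus) for inhibition of Fatty-acid amide hydrolase 1 (Homo sapiens) (on this read-out higher numbers stand for weaker inhibition and lower numbers for stronger inhibition), compound 2 gives 7 nM, the higher of the two numbers recorded. Among the compounds with values here, compound 1 gives 0.6 nM, and the only measured step, a 12-fold higher number from compound 1 to compound 2 (1.07 log units; beyond the scatter), separates them. Compound 3 `CC(=O)c1cnc(C(=O)CCCCCCc2ccccc2)o1` has not yet been measured. It differs from compound 2 at the carbonyl carbon attached to the shared core: methyl in place of methylamino on a carbonyl carbon. Within the data shown here, no measured step involves this kind of replacement; the one step available, a 12-fold higher number from compound 1 to compound 2 (1.07 log units; beyond the scatter), concerns a different group on the same core and so offers no direct guide. With the carbonyl kept and only the methylamino exchanged for methyl, a modest shift is expected rather than a large one, and the estimate is a step of a 1.4-fold higher number from compound 2 to compound 3 (0.15 log units; within the scatter), so compound 3 is expected to lie close to compound 2. Compound 3 is therefore estimated at 10 nM, with a range of 3 nM to 40 nM.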

Compound 3, inhibition constant: 2 nM
Estimate against measurement, compound 3: 5.0-fold (0.70 log units) above, and the stated range ends above it.
By their numbers in this assay, from the lowest: compound 1; then compound 3; then compound 2.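

In this assay, the exchange of methylamino for methyl on a carbonyl carbon gives a 3.5-fold lower number from compound 2 to compound 3 (0.54 log units; beyond the scatter), so at this position the hydrogen-bond donor counted on the methylamino is not needed for a low number, and its loss brings a modest gain rather than a penalty. The acetyl group does not close the whole gap, however: a 3.3-fold higher number from compound 1 to compound 3 (0.52 log units; beyond the scatter) still separates it from the 4-methylpyridin-2-yl group on the same aromatic carbon, and compound 1 keeps the lowest number of the three. No measurement shown here explains why methyl does better than methylamino. From the compounds shown here alone, it remains open whether a larger ketone such as propanoyl, or a carboxylic acid or an unsubstituted amide, would extend or reverse this step. The compounds shown also leave open whether the same exchange would hold with a shorter or longer chain on the other carbonyl.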